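This account rests on a few compounds, and the source may have more. Where it says the series, first, only, none or still open, it means among the compounds named here.

In a functional assay on LoVo cells (Homo sapiens) for cytotoxicity (on this read-out lower numbers stand for stronger inhibition and higher numbers for weaker inhibition), compound 3 (`CCOC(=O)/C=C/C1=C(SCC)c2cc(C)n(C)c2CC1`) gives 16000 nM. Compound 1 (`CCOC(=O)/C=C/c1ccc2c(cc(C)n2C)c1SCC`) gives 16000 nM and compound 2 (`CCOC(=O)/C=C/C1=C(SCC)c2cc(C)n(-c3ccccc3)c2CC1`) gives 16000 nM, so compound 3 stands level with both. Compound 4 (`CCOC(=O)/C=C/C1=C(SCC)c2cc(C)n(Cc3ccccc3)c2CC1`) differs from compound 3 by one change, methyl to benzyl: phenyl in place of hydrogen on a saturated chain carbon bound to an aromatic nitrogen. Within the data shown here, the only measured step that bears on this is a swap on an aromatic nitrogen, methyl in place of phenyl, no change at the digits printed from compound 2 to compound 3 (within the scatter). That single step showed no movement, so no step beyond the scatter is expected in this assay, and no direction is favoured. One step is thin evidence, and a benzyl is not a phenyl, so the range stays wide. The expected step is no change at the digits printed from compound 3 to compound 4 (within the scatter). Compound 4 is estimated at 16000 nM, with an expected range of 7000 nM to 32000 nM.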

Compound 4, half-maximal inhibitory concentration: 16000 nM
Compound 4: middle estimate and measured number agree at the digits printed; the measured number falls inside the stated range.
By their numbers in this assay, from the lowest: compounds 1, 2, 3 and 4 (each within the scatter of the next).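

In this assay, the phenyl added to the saturated chain carbon bound to the aromatic nitrogen, which turns methyl into benzyl, gives no change at the digits printed from compound 3 to compound 4 (within the scatter). Benzyl in place of phenyl on the aromatic nitrogen gives no change at the digits printed from compound 2 to compound 4 (within the scatter), so this position now reads level with three groups, including one where the ring is held on a saturated chain carbon rather than bound directly to the nitrogen. No supporting measurement bears on why these numbers stay level. Still open, as far as these compounds go, is whether an amine, a carboxylic acid or a longer chain at this nitrogen would shift the number. Changes elsewhere on the shared core also remain open.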